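The compounds below may be only part of what the source reports. "The series", "measured", "known", "first", "only" and "open" are said of these compounds alone.

Measured in a physicochemical assay for solubility, measured as kinetic solubility; a lower number here means a less soluble compound, a higher number a more soluble compound:
- Compound 1 `O=C(Nc1ccnnc1)c1cc(N2CCCCC2)ccc1OCc1ccccc1`: 60000 nM
- Compound 2 `O=C(Nc1cccc(Cl)c1)c1cc(C(F)(F)F)ccc1OCc1ccccc1`: 7000 nM
- Compound 3 `O=C(Nc1cccc(F)c1)c1cc(C(F)(F)F)ccc1OCc1ccc(F)cc1`: < 1000 nM

Going by the values given here, only two of these three compounds have actual numbers. Compound 1, at 60000 nM, holds the higher of the two, and compound 2, at 7000 nM, lies lower by a gap beyond the usual scatter. Compound 3 gives no number, and its < 1000 nM is a limit of the assay.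

The account now turns to compound 4 `CN1CCN(c2ccc(OCc3ccccc3)c(C(=O)Nc3ccnnc3)c2)CC1`, which has not yet been measured. It keeps the core of compound 1 and carries 4-methylpiperazin-1-yl in place of piperidin-1-yl on an aromatic carbon, meta to a (pyridazin-4-yl)carbamoyl group and para to a benzyloxy group: 4-methylpiperazin-1-yl in place of piperidin-1-yl on an aromatic carbon.

No measured pair among these compounds shows this change, and compounds 2 and 3 differ from compound 1 in more than one place, so they give no direct guide to its size. The starting point is therefore compound 1 at 60000 nM, and only a small rise is expected, one that stays within the scatter. In numbers, the expected change is a 1.4-fold higher number from compound 1 to compound 4 (0.15 log units; within the scatter).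

For compound 4 the estimated value in this assay is 85000 nM, with an expected range from 35000 nM to 200000 nM.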

Compound 4, solubility: 228000 nM
Beside the measured number, compound 4's estimate is 2.7-fold (0.43 log units) below it, and the stated range ends below it.
By their numbers in this assay, from the lowest: compound 2; then compound 1; then compound 4. At a limit, below all of these: compound 3.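

At the aromatic carbon meta to a (pyridazin-4-yl)carbamoyl group and para to a benzyloxy group, compounds 1 and 4 form the only pair shown that differs in one place, so this position can now be judged directly. In this assay, 4-methylpiperazin-1-yl in place of piperidin-1-yl gives a 3.8-fold higher number from compound 1 to compound 4 (0.58 log units; beyond the scatter) and shows that the read-out responds to the group at this position while the rest of the core of compound 1 stays the same. Nothing measured here accounts for the size of this step.

The compounds shown leave open whether the step depends on the methyl group, which unsubstituted piperazin-1-yl would test, or on the second ring nitrogen, which morpholin-4-yl, with a ring oxygen in its place, would test. They also leave open whether the same change would give a step of similar size with another group in place of the (pyridazin-4-yl)carbamoyl group or the benzyloxy group.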